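A few compounds are considered here, and "the series" means these few. Any claim that something is new, unique, unknown or untested is made for them only; others in the source may bear on it.

Compound 1, `CC1CN(c2nc(=O)c3cc(C(F)(F)F)cc([N+](=O)[O-])c3o2)CCN1CC1CCCCC1`: 10.9 ug/mL
Compound 2, `O=c1nc(NCC2CCCCC2)oc2c([N+](=O)[O-])cc(C(F)(F)F)cc12`: 29.7 ug/mL

Both compounds were tested in an ADME assay on Vero cells (Chlorocebus sabaeus) for cytotoxicity, read by MTT assay, with a stated time of 48 h; on this read-out lower numbers stand for stronger inhibition and higher numbers for weaker inhibition. Compound 1 gives 10.9 ug/mL, which is the lower of the two numbers and therefore the stronger cytotoxic effect seen so far. Compound 2 gives 29.7 ug/mL, a higher number, and the gap between the two lies beyond the usual scatter of repeated measurements, so the difference between them is real. Among the compounds with values here, the two compounds differ in more than one place, so no single-change step between them can be stated.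

Compound 3, `O=c1nc(N2CCN(CC3CCCCC3)CC2)oc2c([N+](=O)[O-])cc(C(F)(F)F)cc12`, has not yet been measured in this assay. It differs from compound 1 in one place: hydrogen in place of methyl on a saturated ring carbon. This is a small change, a single carbon removed from a saturated ring carbon, while the rest of the molecule is kept. A change of this size is expected to move the number little, most likely within the scatter, with a slight lean towards a higher number. The step from compound 1 to compound 3 is expected to be a 1.3-fold higher number from compound 1 to compound 3 (0.11 log units; within the scatter). Compound 3 is therefore estimated at 14 ug/mL, with a range from 6 ug/mL to 35 ug/mL.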

Compound 3, half-maximal inhibitory concentration: 52.1 ug/mL
The estimate for compound 3 lay 3.7-fold (0.57 log units) below the measured number; the whole stated range lies below it.
By their numbers in this assay, from the lowest: compound 1; then compounds 2 and 3 (each within the scatter of the next).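

In this assay, taking away the methyl on this saturated ring carbon and leaving hydrogen gives a 4.8-fold higher number from compound 1 to compound 3 (0.68 log units; beyond the scatter), so a change of a single carbon is enough to move the number past ordinary repeat variation. Within the data shown here, this is the first direct sign that this ring carbon is not a neutral spot on the molecule: the rest of the structure stays the same, and the compound carrying the methyl has the lower number, which on this read-out means the stronger cytotoxic effect. Nothing measured here explains why so small a change has this effect.

The compounds shown carry only hydrogen or methyl on this ring carbon, so it remains open whether a larger or different group there, such as ethyl or hydroxymethyl, would lower the number further, raise it, or leave it in place. One matched pair also cannot tell whether the same swap would act in the same direction if a benzyl group stood in place of the cyclohexylmethyl group on the ring nitrogen.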